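Swapping bromo for fluoro on an anticonvulsant-type amide

This account rests on a few compounds, and the source may have more. Where it says the series, first, only, none or still open, it means among the compounds named here.

Measured so far:
compound 1, `C/C(C(=O)NC1CC1)=C(\C)c1ccc(Br)cc1`: 52.4 mg/kg
compound 2, `C/C(C(=O)NC1CC1)=C(/C)c1ccc(Br)cc1`: 8.2 mg/kg

Both compounds were tested in a functional assay on the whole organism (strain Icem-CET (SPF Caw)) for inhibition, with Mus musculus as the target, with a stated time of 30 min; a higher number here means that more compound is needed for the effect, a lower number that less compound is needed. Compound 2 gives the lowest of the two numbers; its nearest neighbour is compound 1, and the step of a 6.4-fold lower number from compound 1 to compound 2 (0.81 log units; beyond the scatter) lies beyond the scatter. This step is tied to the fact that compounds 1 and 2 differ only in the configuration as drawn: the two share every atom and bond, and only the drawn geometry of the double bond differs.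

The next compound, compound 3 `C/C(C(=O)NC1CC1)=C(/C)c1ccc(F)cc1`, keeps the geometry of compound 2 and changes one thing: fluoro in place of bromo on an aromatic carbon. Among the measured compounds shown here, no measured step here touches a halogen; the only step available, the one from compound 1 to compound 2, concerns the double bond and says nothing directly about this exchange. The expectation therefore rests on compound 2 alone, with a broad allowance for an exchange that has not been seen. Compound 3 is expected to give about 14 mg/kg, between 5 mg/kg and 40 mg/kg, which means an expected step of a 1.7-fold higher number from compound 2 to compound 3 (0.23 log units; within the scatter), likely within or only slightly beyond the scatter.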

Compound 3, dose for half-maximal effect: 25 mg/kg
The estimate for compound 3 lay 1.8-fold (0.25 log units) below the measured number; low and high end bracket the measured number.
By their numbers in this assay, from the lowest: compound 2; then compound 3; then compound 1.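

In this assay, among the compounds shown here, the earlier compounds showed only that the geometry of the double bond matters; this result shows that the halogen matters too. Fluoro in place of bromo, on an aromatic carbon para to a large group, gives a 3.0-fold higher number from compound 2 to compound 3 (0.48 log units; beyond the scatter), so more compound is needed with fluoro than with bromo, and this place on the ring is not indifferent to which of the two halogens sits there, at least with the double bond drawn as in compound 2. The one available fact about these compounds concerns only the drawn geometry of the double bond and has no bearing on the exchange of halogens, so nothing here accounts for the size or direction of this step.

The compounds shown leave open how a chloro group, a methoxy group or an amine would fare at the same place on the ring, so two halogens give a comparison but not yet a trend. They also leave open whether fluoro would give a similar step with the double bond drawn as in compound 1.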